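The source may report more compounds than this note shows. Statements on the series, on what has been measured and on what is new or still open speak of the compounds shown alone.

Compound 3 `Cc1nc(S(C)(=O)=O)ccc1Oc1ncnc(OC2CCN(C(=O)C(C)(F)F)CC2)c1F` is the starting point of this step. In a functional assay on isolated protein for inhibition of Glucose-dependent insulinotropic receptor (Rattus norvegicus), read by HTRF and cAMP accumulation (a lower number here means a smaller maximal response, a higher number a larger maximal response), compound 3 gives 87%. Among the three compounds measured it stands second highest: compound 1 `Cc1nc(S(C)(=O)=O)ccc1Oc1ncnc(OC2CCN(C(=O)OC(C)(C)CF)CC2)c1F` gives 95% in this assay, and compound 2 `Cc1nc(S(C)(=O)=O)ccc1Oc1ncnc(OC2CCN(C(=O)O[C@@H](C)CF)CC2)c1F` gives 84% in this assay. The gap from compound 3 to either of these two lies within the scatter, so compound 3 cannot be placed above or below them on these numbers.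

Compound 4 `Cc1nc(S(C)(=O)=O)ccc1Oc1ncnc(OC2CCN(C(=O)C3CCCC3)CC2)c1F` differs from compound 3 in one place: cyclopentyl in place of 1,1-difluoroethyl on a carbonyl carbon. Among the compounds with values here, two measured steps concern the same carbonyl carbon and therefore bear on this change. The first is a number 8 percentage points lower from compound 1 to compound 3 (within the scatter). The second is a number 3 percentage points higher from compound 2 to compound 3 (within the scatter). Both lie within the scatter, so exchanging the group on this carbonyl carbon has so far left the maximal response essentially unchanged. The remaining step, a number 11 percentage points lower from compound 1 to compound 2 (beyond the scatter), sits at a different place and bears only loosely on the present change.

Compound 4 is therefore expected to give about 87% in this assay, with a range from 74% to 98%. The step of no change at the digits printed from compound 3 to compound 4 (within the scatter) is expected to stay within the scatter.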

Compound 4, largest response reached (reported as efficacy), in percent of the reference or control that the assay uses: 83%
Compound 4: the middle estimate sits 4 percentage points above what was measured; the range from low to high includes it.
By their numbers in this assay, from the lowest: compounds 4, 2, 3 and 1 (each within the scatter of the next, the first and the last beyond it).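

In this assay, a ring of carbon only is tolerated on this carbonyl carbon: cyclopentyl in place of 1,1-difluoroethyl gives a number 4 percentage points lower from compound 3 to compound 4 (within the scatter), and the step to compound 4 from the carbamate-bearing compound 2 reads a number 1 percentage points lower from compound 2 to compound 4 (within the scatter), so neither fluorine nor an open chain is needed at this place to keep the response in this range. Within the data shown here, the exchange starting from compound 1 is different, giving a number 12 percentage points lower from compound 1 to compound 4 (beyond the scatter), which is the first exchange of the whole group on this carbonyl carbon to pass beyond the scatter, although it is a modest step and compound 3 still lies within the scatter of compound 1. Nothing available accounts for these numbers.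

On these data alone, it remains open whether rings of other sizes, such as cyclopropyl or cyclohexyl, or a cyclopentyl ring carrying an amine or a carboxylic acid, would hold the maximal response on this carbonyl carbon. The compounds shown also leave open whether a fluorine on the cyclopentyl ring would bring compound 4 closer to compound 1.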